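Compound 1: 4-methylphenyl for 3-chlorophenyl

A few compounds are considered here, and "the series" means these few. Any claim that something is new, unique, unknown or untested is made for them only; others in the source may bear on it.

Measured so far:
- compound 1 `O=C(/C=C/c1ccc(/C=C/C(=O)c2cccc(Cl)c2)o1)NO` gives 18900 nM
- compound 2 `O=C(NO)c1ccc(/C=C/c2ccccc2O)o1` gives 79200 nM
- compound 3 `O=C(/C=C/c1ccc(/C=C/C(=O)c2cc(Cl)ccc2Cl)o1)NO` gives 27100 nM

All three values come from a functional assay on A549 cells (Homo sapiens) for antiproliferative activity, read by MTT assay, with a stated time of 48 h (on this read-out lower numbers stand for stronger inhibition and higher numbers for weaker inhibition), and are the only data at hand. Compound 1 (18900 nM) sits level with compound 3 (27100 nM) within the scatter, while compound 2 shows the higher number (79200 nM).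

Compound 4 `Cc1ccc(C(=O)/C=C/c2ccc(/C=C/C(=O)NO)o2)cc1` is still unmeasured. Its difference from compound 1 reads 4-methylphenyl in place of 3-chlorophenyl on a carbonyl carbon and amounts to 4-methylphenyl in place of 3-chlorophenyl on a carbonyl carbon. Going by the values given here, the one measured step on this aromatic group is a 1.4-fold higher number from compound 1 to compound 3 (0.16 log units; within the scatter) (chloro in place of hydrogen on an aromatic carbon), and it stays within the scatter. Among the compounds with values here, no measured step removes the chloro group or brings in a methyl group, so this support is thin. On that step alone, no change beyond the scatter is expected in this assay in either direction. The estimated step is a 1.2-fold higher number from compound 1 to compound 4 (0.07 log units; within the scatter) and carries no firm direction. The estimated value for compound 4 is 22000 nM with 10000 nM to 50000 nM as the expected range.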

Compound 4, half-maximal inhibitory concentration: 48600 nM
Beside the measured number, compound 4's estimate is 2.2-fold (0.34 log units) below it; measured number inside the range.
By their numbers in this assay, from the lowest: compounds 1, 3, 4 and 2 (each within the scatter of the next, the first and the last beyond it).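

In this assay, going by these compounds alone, 4-methylphenyl in place of 3-chlorophenyl on the carbonyl carbon gives a 2.6-fold higher number from compound 1 to compound 4 (0.41 log units; beyond the scatter), the first step at this aromatic group to pass the scatter, though a modest one. The earlier step at this group, a 1.4-fold higher number from compound 1 to compound 3 (0.16 log units; within the scatter), stayed within the scatter, so this position is not indifferent to every change of its substituents. The entering and leaving groups match in heavy-atom count and in hydrogen-bond donor and acceptor counts, and nothing at hand explains the step.

This single exchange removes the chloro group, brings in a methyl group and alters the substitution pattern, and the compounds shown do not separate these parts. Phenyl, 3-methylphenyl or 4-chlorophenyl on the same carbonyl carbon would be needed to tell them apart.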